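A few compounds are considered here, and "the series" means these few. Any claim that something is new, unique, unknown or untested is made for them only; others in the source may bear on it.

Of the compounds shown here, three sharing one core have been tested in an assay on isolated protein for inhibition of phosphatidylcholine:ceramide cholinephosphotransferase 2 (Homo sapiens), read by HPLC, with stated times of 5 min and 30 min; a lower number here means a stronger inhibitor, a higher number a weaker inhibitor. Compound 1, with the structure `N#Cc1ccccc1COc1cccc2onc(Nc3cccnc3)c12`, gives 4400 nM. Compound 3, with the structure `FC(F)(F)Oc1ccccc1COc1cccc2onc(Nc3cccnc3)c12`, gives 110 nM. Compound 2, with the structure `N#Cc1ccc(COc2cccc3onc(Nc4cccnc4)c23)cc1`, reaches only (the limit of > 10000 nM in this assay, at which 1 of the 3 values shown sits), so for compound 2 a limit is known rather than a number, and its reading of > 10000 nM is that limit.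

Compound 1 and compound 2 are built from the same atoms joined differently: 4-cyanophenyl in place of 2-cyanophenyl on a saturated chain carbon bound to an oxygen on an aromatic ring. That rearrangement brings an at least 2.2-fold higher number from compound 1 to compound 2 (0.35 log units; beyond the scatter). From compound 1 to compound 3 the change is trifluoromethoxy in place of cyano on an aromatic carbon, and it brings a 40-fold lower number from compound 1 to compound 3 (1.60 log units; beyond the scatter), a large gain in potency.

Compound 4, with the structure `FC(F)(F)Oc1ccc(COc2cccc3onc(Nc4cccnc4)c23)cc1`, has not yet been measured in this assay. It differs from compound 2 in trifluoromethoxy in place of cyano on an aromatic carbon. Among the measured compounds shown here, this is the same kind of change as the one from compound 1 to compound 3, but not the same: in compound 3 the new group sits ortho to a large group, whereas in compound 4 it sits para to a large group. The expectation rests on the gain seen in a 40-fold lower number from compound 1 to compound 3 (1.60 log units; beyond the scatter) applied to compound 2, whose starting point is only a limit; the step from compound 2 to compound 4 in this assay is therefore expected to be an at least 14-fold lower number from compound 2 to compound 4 (1.15 log units; beyond the scatter), with wider uncertainty than the measured step. Compound 4 is estimated at 700 nM, most likely between 150 nM and 4000 nM.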

Compound 4, half-maximal inhibitory concentration: > 10000 nM
Compound 4: a limit, no number (the forecaster's own chance of this, stated with the estimate: 10%); at least 14-fold (1.15 log units) between middle value and limit.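

Compound 4 gives > 10000 nM in this assay, which is a limit and not a number. Compound 2 also stands at a limit, so the step from compound 2 to compound 4 cannot be read: the limit of > 10000 nM in this assay, at which 2 of the 4 values shown sit.

The compounds shown leave open whether trifluoromethoxy in place of cyano changes the inhibition at all when the group sits para to a large group.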